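Bromo for Chloro on Two Different Cores

The compounds below may be only part of what the source reports. "The series", "measured", "known", "first", "only" and "open" are said of these compounds alone.

Compound 1, with the structure `COc1cccc(C2=NNC(c3ccc(Cl)cc3)C2O)c1`, and compound 2, with the structure `COc1cccc(C2=NNC(c3ccc(Br)cc3)C2O)c1`, share one core. In a functional assay on MCF7 cells (Homo sapiens) for antiproliferative activity, read by sulforhodamine B assay, with a stated time of 48 h (on this read-out higher numbers stand for weaker inhibition and lower numbers for stronger inhibition), compound 1 gives 49 nM, and compound 2 gives 49 nM. The change between them is bromo in place of chloro on an aromatic carbon, and the step it made is no change at the digits printed from compound 1 to compound 2 (within the scatter). Compound 3, with the structure `COc1cc(C2=CC(c3ccc(Cl)cc3)NC(=S)N2)cc(OC)c1OC`, rests on a second core; the difference between the two cores is not broken down here. In this assay compound 3 gives 120 nM. Compound 4, with the structure `COc1cc(C2=CC(c3ccc(Br)cc3)NC(=S)N2)cc(OC)c1OC`, carries the same change against compound 3: bromo in place of chloro on an aromatic carbon. Because the step of no change at the digits printed from compound 1 to compound 2 (within the scatter) stayed within the scatter, the step of no change at the digits printed from compound 3 to compound 4 (within the scatter) is expected to be equally flat. Compound 4 is therefore estimated at 120 nM, expected between 60 nM and 240 nM.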

Compound 4, half-maximal inhibitory concentration: 77 nM
For compound 4 the middle estimate is 1.6-fold (0.19 log units) above the measured one; the range from low to high includes it.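

In this assay the swap from 4-chlorophenyl to 4-bromophenyl gives a 1.6-fold lower number from compound 3 to compound 4 (0.19 log units; within the scatter) on the second core, so it stays flat there as it did on the first. Set side by side, the two steps agree: the same change on two cores in this assay, no change at the digits printed (within the scatter) from compound 1 to compound 2 and a 1.6-fold lower number (0.19 log units; within the scatter) from compound 3 to compound 4, 1.6-fold (0.19 log units) apart, within the scatter of two such steps. This shows that the swap carried over between these two cores in this assay, but two pairs are a small sample and say nothing about a further core or a different kind of assay.

The compounds shown leave open whether other groups in the same place on the ring, such as fluoro, methyl or an amine, would behave like chloro and bromo. They also leave open how each difference between the two cores contributes to activity.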